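Taking the chloro group off a weak growth inhibitor

The compounds below may be only part of what the source reports. "The series", "measured", "known", "first", "only" and "open" are said of these compounds alone.

Within the data shown here, in a functional assay on SK-MEL-5 cells (Homo sapiens) for antiproliferative activity (on this read-out lower numbers stand for stronger inhibition of growth and higher numbers for weaker inhibition of growth), compound 1 (`COc1cc(-n2cc(-c3ccc(Cl)cc3)[nH]c2=O)cc(OC)c1OC`) gives 31600 nM as the only true number among the three compounds tested so far. Compound 2 (`COc1cc(-c2cn(-c3ccc(Cl)cc3)c(=O)[nH]2)cc(OC)c1OC`) is reported only as a limit of > 100000 nM in this assay and so has no exact value. Compound 3 (`COc1ccc(-n2cc(-c3ccc(OC)c(OC)c3)[nH]c2=S)cc1Cl`) is likewise reported only as a limit of > 100000 nM in this assay and has no exact value either.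

Compound 4 (`COc1cc(-n2cc(-c3ccccc3)[nH]c2=O)cc(OC)c1OC`) keeps the core of compound 1 and differs in one place, with hydrogen in place of chloro on an aromatic carbon. The 4-chlorophenyl thus becomes phenyl. Among the measured compounds shown here, no measured pair shows this change on its own, so the expectation rests on compound 1 with its 31600 nM reading and on the structural change. A small step toward weaker inhibition of growth is expected, possibly no larger than the usual scatter. The estimate is a 1.6-fold higher number from compound 1 to compound 4 (0.20 log units; within the scatter) in that direction. In this assay compound 4 is expected at 50000 nM (estimated range 15000 nM to 100000 nM).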

Compound 4, concentration for 50% growth inhibition: 39800 nM
The estimate for compound 4 lay 1.3-fold (0.10 log units) above the measured number; measured number inside the range.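

In this assay, replacing the chloro group with hydrogen gives a 1.3-fold higher number from compound 1 to compound 4 (0.10 log units; within the scatter). Among these compounds, this pair is the first direct look at this change on an aromatic carbon para to a large group, since no earlier pair of compounds differed in one place only. Within this pair, the 4-chlorophenyl and the phenyl cannot be told apart, so the chloro group is not needed to keep this level of growth inhibition.

One swap cannot show whether another group at this position, such as an amine, a carboxylic acid or a longer chain, would shift the number beyond the scatter or would give much stronger inhibition of growth. Exact numbers also remain scarce among the compounds shown, which leaves little to compare: the limit of > 100000 nM in this assay, at which 2 of the 4 values shown sit.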